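Shortening the Alkyl Chain on a Nucleoside Scaffold

The source may report more compounds than this note shows. Statements on the series, on what has been measured and on what is new or still open speak of the compounds shown alone.

Measured compounds:
compound 1 `CCCc1ccc(-c2cc3cn([C@H]4C[C@H](O)[C@@H](CO)O4)c(=O)nc3s2)cc1` — > 200000 nM
compound 2 `CCCCCCc1ccc(-c2cc3cn([C@H]4C[C@H](O)[C@@H](CO)O4)c(=O)nc3s2)cc1` — > 200000 nM

In a functional assay on HeLa cells (Homo sapiens) for cytotoxicity (on this read-out higher numbers stand for lower toxicity in this test and lower numbers for higher toxicity in this test), compound 1 gives > 200000 nM, which is a limit of the assay rather than a measured number. In this assay compound 2 likewise gives > 200000 nM, also a limit. The step that the two limits leave unreadable from compound 1 to compound 2 therefore cannot be read in size or direction because the limit of > 200000 nM in this assay, at which 2 of the 2 values shown sit, holds for both compounds; all that the numbers show is that compound 2 stands at the same limit as compound 1.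

Compound 3 `CCc1ccc(-c2cc3cn([C@H]4C[C@H](O)[C@@H](CO)O4)c(=O)nc3s2)cc1` is the next member of this series. It differs from compound 2 by hydrogen in place of butyl on a saturated chain carbon, two bonds along the chain from an aromatic carbon. Within the data shown here, the only measured step, the one from compound 1 to compound 2, also moved along this chain, and it left both compounds at the limit. On that basis no step beyond the usual scatter is expected in this assay; the step of a number no higher from compound 2 to compound 3 (the limit leaves the size open) is estimated to be flat. Compound 3 is thus expected to show 200000 nM, within a range from 100000 nM to 400000 nM, most likely again reported as a limit.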

Compound 3, half-maximal cytotoxic concentration: > 200000 nM
Compound 3: only a limit was reported; the forecaster's own chance of this, stated with the estimate: 85%; the middle value lies on the limit itself.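

In this assay compound 3 gives > 200000 nM, which is a limit and not a measured number. The steps among compound 1, compound 2 and compound 3 therefore cannot be read, in size or in direction, because all three stand at the same limit: the limit of > 200000 nM in this assay, at which 3 of the 3 values shown sit.

The compounds shown leave open whether, in this assay, the ethyl, propyl and hexyl chains differ at all.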